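Trifluoromethyl to Amino: One Change on a Shared Core

The compounds below may be only part of what the source reports. "The series", "measured", "known", "first", "only" and "open" are said of these compounds alone.

Compound 1 `C/C(=N\NC(=O)c1ccc(C(F)(F)F)cc1)c1cnccn1` and compound 2 `C/C(=N\NC(=O)c1cccs1)c1cnccn1` have both been tested in an ADME assay on MRC5 cells (Homo sapiens) for antiproliferative activity, read by MTT assay; a higher number here means a weaker inhibitor, a lower number a stronger inhibitor. Compound 1 gives 2090 nM, the lower of the two numbers; compound 2 gives 5540 nM, a higher number that lies beyond the usual scatter. Compound 3 `C/C(=N\NC(=O)c1ccc(N)cc1)c1cnccn1` is not yet measured. It differs from compound 1 in one place: amino in place of trifluoromethyl on an aromatic carbon. Within the data shown here, no measured pair shows this exact change, so the expectation rests on the change itself. For compound 3 the step is expected to be modest and toward a higher number, a 2.9-fold higher number from compound 1 to compound 3 (0.46 log units; beyond the scatter). Compound 3 is estimated at 6000 nM, within a range from 2000 nM to 20000 nM.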

Compound 3, half-maximal inhibitory concentration: > 80000 nM
Compound 3 ended at the assay's limit (the forecaster's own chance of this, stated with the estimate: 20%); middle value at least 13-fold (1.12 log units) away from the limit.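

this assay is strongly sensitive to the group at this place on the ring: amino in place of trifluoromethyl gives an at least 38-fold higher number from compound 1 to compound 3 (1.58 log units; beyond the scatter). The earlier compounds shown here showed no change at this position, and this single change takes the number far beyond the scatter. For compound 3 the reading is a limit of the assay, not a number: the limit of > 80000 nM in this assay, at which 1 of the 3 values shown sits.

On these data alone, what drives the step stays open, as does how far it reaches. Whether a methyl group, a chlorine atom or a carboxylic acid at this same place would keep the number of compound 1 or follow compound 3 cannot be told from these compounds.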